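Swapping 1-phenylethyl for 2-methylphenyl

This account rests on a few compounds, and the source may have more. Where it says the series, first, only, none or still open, it means among the compounds named here.

Values in a physicochemical assay for solubility, with a stated time of 24 h, tested at 30 mg/mL (a higher number here means a more soluble compound, a lower number a less soluble compound), are as follows
- Compound 1 `O=C(CCCCCNc1c(Nc2ccccc2)c(=O)c1=O)NO` gives 2200000 nM
- Compound 2 `O=C(CCCCCNc1c(NCc2ccccc2)c(=O)c1=O)NO` gives 5700000 nM
- Compound 3 `C[C@H](Nc1c(NCCCCCC(=O)NO)c(=O)c1=O)c1ccccc1` gives 28000000 nM

Compound 3 has the highest number of the three. Compound 4 `Cc1ccccc1Nc1c(NCCCCCC(=O)NO)c(=O)c1=O` carries 2-methylphenyl in place of 1-phenylethyl on a nitrogen on an aromatic ring and loses the defined stereocentre. Among the compounds with values here, two measured steps bear on this: a 13-fold higher number from compound 1 to compound 3 (1.10 log units; beyond the scatter) was large and a 4.9-fold higher number from compound 2 to compound 3 (0.69 log units; beyond the scatter) was modest. Compound 1, with its phenyl, sits lowest, and the entering group is also a phenyl, one carrying a methyl. No measurement shows what that methyl does here. A drop somewhat smaller than the first step is therefore expected, and the expected step is an 8.0-fold lower number from compound 3 to compound 4 (0.90 log units; beyond the scatter) in this assay overall. Compound 4 is estimated at 3500000 nM with an expected range of 1300000 nM to 10000000 nM for repeat measurements.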

Compound 4, solubility: 12000000 nM
Estimate against measurement, compound 4: 3.4-fold (0.54 log units) below; the whole stated range lies below it.
By their numbers in this assay, from the lowest: compound 1; then compound 2; then compound 4; then compound 3.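

In this assay, a single methyl on an aromatic carbon separates compound 1 from compound 4, and that one change gives a 5.5-fold higher number from compound 1 to compound 4 (0.74 log units; beyond the scatter) on its own. The 2-methylphenyl group sits between the two other groups, with a 2.1-fold higher number from compound 2 to compound 4 (0.32 log units; beyond the scatter) against benzyl and a 2.3-fold lower number from compound 3 to compound 4 (0.37 log units; beyond the scatter) against 1-phenylethyl, so a defined stereocentre is not needed to rise above compound 2. No measurement here gives a reason for these steps. On these data alone, whether an ethyl, a methoxy or an amine on the phenyl would behave like the methyl remains open.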